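The compounds below may be only part of what the source reports. "The series", "measured", "known", "first", "only" and "open" are said of these compounds alone.

Compound 1, `CC(C)C[C@H](N)c1cc(C(F)(F)F)ccc1N1CCN(C(=O)[C@H](C)Cc2ccc(Cl)cc2)CC1`, is the weakest binder among the three measured compounds: in an assay on HEK293 cells for displacement of a labelled ligand from Melanocortin receptor 4 (Homo sapiens) (on this read-out higher numbers stand for weaker inhibition and lower numbers for stronger inhibition), compound 1 gives 31 nM, the highest of the three numbers. Compound 2, `COc1cc(Cl)ccc1C[C@@H](C)C(=O)N1CCN(c2ccc(C)cc2[C@@H](N)CC(C)C)CC1`, gives 8.1 nM in this assay, and compound 3, `COc1cc(Cl)ccc1CC(C)C(=O)N1CCN(c2ccc(Cl)cc2[C@@H](N)CC(C)C)CC1`, gives 9.1 nM; both sit beyond the scatter from compound 1, while compound 2 and compound 3 lie within the scatter of each other. The unmeasured compound 4, `Cc1ccc(OCC(=O)N2CCN(c3ccc(C(F)(F)F)cc3[C@@H](N)CC(C)C)CC2)c(C)c1`, differs from compound 1 in a single place: (2,4-dimethylphenoxy)methyl in place of 1-(4-chlorobenzyl)ethyl on a carbonyl carbon. Within the data shown here, no measured pair shows this kind of change, so the step can only be expected, not read from the data. Compound 4 is expected to give a step of a 1.9-fold higher number from compound 1 to compound 4 (0.29 log units; within the scatter), a modest loss that may still fall within the scatter, with an estimated value of 60 nM and a range from 15 nM to 250 nM.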

Compound 4, inhibition constant: 4000 nM
Beside the measured number, compound 4's estimate is 67-fold (1.82 log units) below it; the measured number lies above the stated range.
By their numbers in this assay, from the lowest: compounds 2 and 3 (each within the scatter of the next); then compound 1; then compound 4.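

Although the two groups on this carbonyl carbon match in heavy-atom count and each holds one six-membered aromatic ring of carbon only, in this assay the change gives a 130-fold higher number from compound 1 to compound 4 (2.11 log units; beyond the scatter), a large step. Equal size and the same ring type are therefore not enough to keep binding at this position, which the earlier compounds, all with a chlorine-bearing group here, did not show. Nothing available explains the loss.

The compounds shown leave open whether the ether oxygen, the two methyl groups or the missing chlorine drives this step, and a chlorophenoxymethyl group on the same carbonyl carbon would help separate these.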